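The compounds below may be only part of what the source reports. "The series", "measured", "known", "first", "only" and "open" are said of these compounds alone.

Measured compounds in a functional assay on Ehrlich cells (Mus musculus) for cytotoxicity, read by trypan blue exclusion, with a stated time of 2 h, tested at 100 ug/mL; on this read-out lower numbers stand for a weaker effect and higher numbers for a stronger effect at the one concentration tested:
- compound 1 `C=CCNC(=S)NC1=C(C#N)C(c2ccc(Cl)cc2Cl)C2=C(CCCC2=O)N1c1ccc(S(N)(=O)=O)cc1`: 40%
- compound 2 `N#CC1=C(NC(=S)Nc2ccccc2)N(c2ccc(S(N)(=O)=O)cc2)C2=C(C(=O)CCC2)C1c1ccc(Cl)cc1Cl`: 95%

Compound 1 stands lowest of the two numbers; compound 2 is the nearest, with a number 55 percentage points higher from compound 1 to compound 2 (beyond the scatter), a change of the group on the amide-type nitrogen only.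

Compound 3 `N#CC1=C(N2C(=O)CCC2=O)N(c2ccc(S(N)(=O)=O)cc2)C2=C(C(=O)CCC2)C1c1ccc(Cl)cc1Cl` is not yet measured. It differs from compound 1 as follows: a group of 7 heavy atoms (4 carbon, 1 nitrogen, 2 oxygen; one five-membered non-aromatic ring with 1 hetero atom) in place of a group of 7 heavy atoms (4 carbon, 2 nitrogen, 1 sulfur; no ring), on a double-bonded ring carbon. The change sits on a double-bonded ring carbon of a six-membered non-aromatic ring with 1 nitrogen, part of a fused or bridged system of two rings, the same position altered between compound 1 and compound 2.

Among the measured compounds shown here, only that one step bears on the question, and it shows the position to be sensitive, since exchanging allyl for phenyl gave a large rise. The 2,5-dioxopyrrolidin-1-yl group is a different kind of change, with no donor left, so the direction is not fixed by the data. A rise from compound 1 is expected but with wide uncertainty: for compound 3 the estimate is 60%, range 25% to 95%, which means an expected step of a number 20 percentage points higher from compound 1 to compound 3 (beyond the scatter).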

Compound 3, a percentage reported as activity, at one concentration (the size of the read-out at that concentration, not a potency): 90%
Compound 3: the middle estimate sits 30 percentage points below what was measured, within the range that was stated.
By their numbers in this assay, from the lowest: compound 1; then compounds 3 and 2 (each within the scatter of the next).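

In this assay, placing the 2,5-dioxopyrrolidin-1-yl group on this double-bonded ring carbon gives a number 50 percentage points higher from compound 1 to compound 3 (beyond the scatter), so the large rise at this position is not confined to the phenyl change and also occurs with a ring group carrying 0 hydrogen-bond donors. The exchange of the larger group gives a number 5 percentage points lower from compound 2 to compound 3 (within the scatter), so in this set sulfur in the group on this carbon is not needed for a high number at the one concentration tested. No measurement on hand accounts for either step.

On these data alone, it remains open whether the ring, its two carbonyls or the absence of donors goes with the high number. A plain amine or an open-chain acetamide on the same carbon would help separate these features.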